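The compounds below may be only part of what the source reports. "The series", "measured", "known", "first", "only" and "open" are said of these compounds alone.

Working notes on the series. Compound 1 `CCc1ccc(OCC(=O)N(CC)Cc2cccs2)cc1` and compound 2 `CCCc1ccc(OCC(=O)N(CC)Cc2cccs2)cc1` share a core and differ at one place. In an assay on HEK293 cells for agonist activity at transient receptor potential cation channel subfamily M member 8 (Homo sapiens), read by fluorescence and calcium flux, with a stated time of 15 min (on this read-out higher numbers stand for an effect only at larger amounts of compound and lower numbers for an effect already at smaller amounts), compound 1 gives 67 nM, and compound 2 gives 1810 nM. The change between them, (hydrogen in place of methyl on a saturated chain carbon, two bonds along the chain from an aromatic carbon), made the step of a 27-fold lower number from compound 2 to compound 1 (1.43 log units; beyond the scatter). Compound 3 `Cc1ccc(OCC(=O)N(Cc2cccs2)C(C)(C)C)cc1` has the same atoms as compound 2 joined differently; the difference between the two cores is not broken down here. In this assay compound 3 gives 11000 nM, the highest number of the three.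

Compound 4 `Cc1ccc(OCC(=O)N(Cc2cccs2)C(C)C)cc1` is not yet measured. It stands to compound 3 as compound 1 stands to compound 2: hydrogen in place of methyl on a saturated chain carbon bound to an amide-type nitrogen and two saturated chain carbons. This is the same kind of change, but the place differs: the earlier one sits on a saturated chain carbon two bonds along the chain from an aromatic carbon, the new one on a saturated chain carbon bound to an amide-type nitrogen and two saturated chain carbons. The earlier step rests on a single pair, on a different core and at a different place, so it does not carry over directly. A lower number is expected for compound 4, with a smaller step than the earlier one: a 3.1-fold lower number from compound 3 to compound 4 (0.50 log units; beyond the scatter). The estimate for compound 4 in this assay is 3500 nM, between 700 nM and 15000 nM.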

Compound 4, half-maximal effective concentration: 70 nM
Compound 4: middle estimate off by 50-fold (1.70 log units), on the high side; measured number below the stated range.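

Going from tert-butyl to isopropyl gives a 160-fold lower number from compound 3 to compound 4 (2.20 log units; beyond the scatter) in this assay, so hydrogen in place of methyl lowers the number on both cores shown. The direction is shared, but the size is not: the same change on two cores in this assay, a 27-fold lower number (1.43 log units; beyond the scatter) from compound 2 to compound 1 and a 160-fold lower number (2.20 log units; beyond the scatter) from compound 3 to compound 4, 5.8-fold (0.76 log units) apart, beyond the scatter of two such steps.
This shows that the change can go the same way on two cores in this series, but not that a step measured on one core sets the size of the step on another. The two pairs differ in core and also in the place of the change, so these two pairs cannot separate the contribution of each, and they give no rule for a further core.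

The compounds shown leave open how a longer chain or a cyclopropyl group would read in place of the isopropyl on the amide-type nitrogen of compound 4. They also leave open whether an amine or a carboxylic acid at the same place would keep a number close to that of compound 4.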